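Ethyl added to the inactive acetyl-hydroxy compound

The source may hold more compounds than are shown below. What is called first, only, known or untested is meant among the compounds shown, and "the series" means these compounds.

Values in a functional assay on ileum (Cavia porcellus) for antagonist activity; a lower number here means a stronger inhibitor, a higher number a weaker inhibitor:
- compound 1 `CCCc1cc(F)ccc1OCC(O)COc1ccc2c(O)c([N+](=O)[O-])c(=O)oc2c1`: 140 nM
- compound 2 `CC(=O)c1ccc(OCC(O)COc2ccc3c(O)c([N+](=O)[O-])c(=O)oc3c2)cc1O`: > 20000 nM

Compound 2 stands at > 20000 nM, which is a limit of the assay and not a number. Compound 3 `CCc1cc(C(C)=O)c(O)cc1OCC(O)COc1ccc2c(O)c([N+](=O)[O-])c(=O)oc2c1` has ethyl in place of hydrogen on an aromatic carbon of compound 2: ethyl in place of hydrogen on an aromatic carbon. Among the measured compounds shown here, the only measured step that bears on this is an at least 140-fold higher number from compound 1 to compound 2 (2.15 log units; beyond the scatter), with 4-acetyl-3-hydroxyphenyl in place of 4-fluoro-2-propylphenyl. That step is large, but it changes more than the ethyl swap does, so it is only a loose guide. Compound 3 keeps the acetyl and hydroxy groups of compound 2 but gains a chain, as compound 1 with its propyl has one, so part of an at least 140-fold higher number from compound 1 to compound 2 (2.15 log units; beyond the scatter) is expected to be recovered. The step expected in this assay is an at least 13-fold lower number from compound 2 to compound 3 (1.12 log units; beyond the scatter), towards a lower number and smaller than the measured one. For compound 3 the estimated value is 1500 nM, with an expected range of 200 nM to 15000 nM.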

Compound 3, half-maximal inhibitory concentration: 3500 nM
Estimate against measurement, compound 3: 2.3-fold (0.37 log units) below, within the range that was stated.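

In this assay, ethyl in place of hydrogen gives an at least 5.7-fold lower number from compound 2 to compound 3 (0.75 log units; beyond the scatter), so this position, ortho to a large group, meta to the acetyl group and para to the hydroxy group, is one where ethyl alone restores measurable activity. The earlier step replaced the whole substituted phenyl at once, whereas this one reads a single substituent with the acetyl and hydroxy groups kept. Compound 2 stands at a limit and not a number, so the full size of this step cannot be read: the limit of > 20000 nM in this assay, at which 1 of the 3 values shown sits.

As far as these compounds go, whether a butyl chain, a methoxy group or an amine at this position would take the value further remains open. Also open, from the compounds shown here alone, is whether ethyl gives a similar gain on a phenyl ring without the acetyl and hydroxy groups.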